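A Phenyl-for-Phenyl Swap on the Amide Carbonyl

The source may hold more compounds than are shown below. What is called first, only, known or untested is meant among the compounds shown, and "the series" means these compounds.

Three amides built on one shared core have been tested in a functional assay on A2780 cells (Homo sapiens) for antiproliferative activity, read by fluorescence, with a stated time of 72 h; a lower number here means a stronger inhibitor, a higher number a weaker inhibitor. Compound 1 `CN1CCC(C(=O)N2Cc3c(NC(=O)C4CCC4)n[nH]c3C2(C)C)CC1`, with cyclobutyl on a carbonyl carbon, gives 140 nM. Compound 2 `CN1CCC(C(=O)N2Cc3c(NC(=O)c4cccs4)n[nH]c3C2(C)C)CC1`, with thiophen-2-yl there, gives 30 nM. Compound 3 `CN1CCC(C(=O)N2Cc3c(NC(=O)c4ccc(F)c(F)c4)n[nH]c3C2(C)C)CC1`, with 3,4-difluorophenyl there, gives 100 nM. The data show a 1.4-fold lower number from compound 1 to compound 3 (0.15 log units; within the scatter), so these two compounds cannot be told apart. They also show a 3.3-fold higher number from compound 2 to compound 3 (0.52 log units; beyond the scatter), a modest gap.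

Compound 4 `CN1CCC(C(=O)N2Cc3c(NC(=O)c4ccc(C(F)(F)F)cc4)n[nH]c3C2(C)C)CC1` has not yet been measured. Its change is 4-(trifluoromethyl)phenyl in place of 3,4-difluorophenyl on a carbonyl carbon. Among the measured compounds shown here, no measured pair compares two substituted phenyl groups, so the only guides are swaps of the whole group at this place. The largest of these is a 4.7-fold lower number from compound 1 to compound 2 (0.67 log units; beyond the scatter), still modest. On these data alone, a swap that keeps the phenyl ring is therefore expected to give no step beyond the scatter in this assay, and its direction stays open. The estimated change is a 1.2-fold higher number from compound 3 to compound 4 (0.08 log units; within the scatter). For compound 4 the expected value is 120 nM, with an estimated range of 40 nM to 320 nM.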

Compound 4, half-maximal inhibitory concentration: 60 nM
Compound 4: middle estimate off by 2.0-fold (0.30 log units), on the high side; measured number inside the range.
By their numbers in this assay, from the lowest: compounds 2, 4, 3 and 1 (each within the scatter of the next, the first and the last beyond it).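

Among the compounds shown here, replacing 3,4-difluorophenyl with 4-(trifluoromethyl)phenyl on this carbonyl carbon gives the first comparison of two substituted phenyl groups here, and in this assay they cannot be told apart (a 1.7-fold lower number from compound 3 to compound 4 (0.22 log units; within the scatter)). Even so, the new group does what 3,4-difluorophenyl did not: it stands clear of cyclobutyl (a 2.3-fold lower number from compound 1 to compound 4 (0.37 log units; beyond the scatter)) and cannot be told apart from thiophen-2-yl (a 2.0-fold higher number from compound 2 to compound 4 (0.30 log units; within the scatter)). No measurement at hand explains these results.

An unsubstituted phenyl group would show how much of this picture depends on the fluorine-bearing substituents at all. On these data alone, it also remains open how a carboxylic acid, an amine or a longer carbon chain would fare on this carbonyl carbon.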